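The compounds below may be only part of what the source reports. "The series", "measured", "known", "first", "only" and "open" are said of these compounds alone.

Measured compounds in a functional assay on B16-F10 cells (Mus musculus) for antiproliferative activity, read by ELISA and MTT assay, with a stated time of 48 h; a lower number here means a stronger inhibitor, a higher number a weaker inhibitor:
compound 1 `Cc1ccc(S(=O)(=O)NC(=O)/C=C/c2ccc(F)cc2)cc1` gives 4.8 ug/mL
compound 2 `O=C(/C=C/c1ccc(F)cc1)NS(=O)(=O)c1ccc(Cl)cc1` gives 2.6 ug/mL
compound 3 `O=C(/C=C/c1ccc(F)cc1)NS(=O)(=O)c1ccc(Br)cc1` gives 2.8 ug/mL

Compound 2 stands at the lowest of the three numbers, but the separations are small: a 1.8-fold lower number from compound 1 to compound 2 (0.27 log units; within the scatter), a 1.7-fold lower number from compound 1 to compound 3 (0.23 log units; within the scatter) and a 1.1-fold higher number from compound 2 to compound 3 (0.03 log units; within the scatter) are all within the scatter, so the three compounds cannot be ranked.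

Compound 4 `COc1ccc(/C=C/C(=O)NS(=O)(=O)c2ccc(Cl)cc2)cc1` differs from compound 2 by methoxy in place of fluoro on an aromatic carbon. For the measured compounds named here, every measured step changes the substituent on the sulfonyl-bearing ring, not the ring carrying the fluoro group, so no step bears directly on this change. Going by the values given here, with no precedent, the expectation is a step of no size beyond the scatter, a 1.1-fold higher number from compound 2 to compound 4 (0.03 log units; within the scatter). Compound 4 is therefore estimated at 2.8 ug/mL, in the range 1.4 ug/mL to 5.6 ug/mL.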

Compound 4, half-maximal inhibitory concentration: 5.3 ug/mL
Compound 4: the middle estimate sits 1.9-fold (0.28 log units) below what was measured; the measured number falls inside the stated range.
By their numbers in this assay, from the lowest: compounds 2, 3, 1 and 4 (each within the scatter of the next, the first and the last beyond it).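

In this assay, methoxy in place of fluoro on an aromatic carbon, para to a large group, gives a 2.0-fold higher number from compound 2 to compound 4 (0.31 log units; beyond the scatter), a modest change. This is the only step shown that lies beyond the scatter, whereas the three steps on the sulfonyl-bearing ring all stay within it, so the ring carrying the fluoro group is not silent to substitution. No measurement on hand accounts for this step.

A single pair cannot show whether the step is particular to methoxy or would also appear with an amine, a hydroxyl or a longer ether chain at this place. On these data alone, whether it carries over with bromo or methyl on the other ring also remains open.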